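From carbamoyl to amino at the limit of the assay

The compounds below may be only part of what the source reports. "The series", "measured", "known", "first", "only" and "open" are said of these compounds alone.

In an ADME assay on Raji cells (Homo sapiens) for cytotoxicity, with a stated time of 72 h (on this read-out lower numbers stand for an effect already at smaller amounts and higher numbers for an effect only at larger amounts of compound), compound 3 (`Cc1cc(NC(=O)Nc2ccc(C(N)=O)cc2)c2ccccc2n1`) gives > 25000 nM as a limit of the assay and not a number. Compound 1 (`Cc1cc(NC(=O)Nc2ccccc2N)c2ccccc2n1`) gives > 25000 nM as a limit too. Compound 2 (`Cc1ccc(NC(=O)Nc2cc(C)nc3ccccc23)cc1`) gives > 25000 nM as a limit as well. Compound 4 (`Cc1cc(NC(=O)Nc2ccc(N)cc2)c2ccccc2n1`) has amino in place of carbamoyl on an aromatic carbon, para to a large group (amino in place of carbamoyl on an aromatic carbon). Within the data shown here, neither a step that the two limits leave unreadable from compound 1 to compound 2 nor a step that the two limits leave unreadable from compound 2 to compound 3 has a size that can be read, so no measured step can be carried over. Compound 4 is expected to stay near the limit because of the limit of > 25000 nM in this assay, at which 3 of the 3 values shown sit, and no step beyond the scatter is expected. The estimated step is a number no higher from compound 3 to compound 4 (the limit leaves the size open) (with no direction expected). For compound 4 the estimate is 25000 nM (expected range 12000 nM to 50000 nM).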

Compound 4, half-maximal effective concentration: > 25000 nM
Compound 4: no number, only a limit; the forecaster's own chance of this, stated with the estimate: 85%; the middle value sits exactly at the limit.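

Compound 4 ends at a limit, as do compound 1, compound 2 and compound 3, so no step among these compounds can be read: the limit of > 25000 nM in this assay, at which 4 of the 4 values shown sit.

The compounds shown leave open whether any of these changes alters the amount needed for an effect in this assay.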